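The compounds below may be only part of what the source reports. "The series", "measured", "known", "first", "only" and "open" are said of these compounds alone.

Three chalcone-type compounds have been tested in a functional assay on SF-539 cells (Homo sapiens) for cytotoxicity, read by sulforhodamine B assay, with a stated time of 48 h, tested at 10 uM; on this read-out lower numbers stand for a stronger effect and higher numbers for a weaker effect at the one concentration tested. Compound 1, `COc1ccc(-c2cc(/C=C/C(=O)c3ccc(N)cc3)[nH]n2)cc1`, gives -61% there. Compound 3, `COc1ccc(-c2cc(/C=C/C(=O)c3ccc(N)cc3)[nH]n2)cc1OC`, carries an extra methoxy in place of hydrogen on an aromatic carbon, ortho to a methoxy group and meta to a large group, a change described by methoxy in place of hydrogen on an aromatic carbon; in this assay compound 3 gives -73%, so a number 12 percentage points lower from compound 1 to compound 3 (beyond the scatter). Compound 2, `COc1ccc(C(=O)/C=C/c2cc(-c3cc(OC)c(OC)c(OC)c3)n[nH]2)cc1OC`, differs from compound 1 in more than one place, and the difference between the two cores is not broken down here; in this assay compound 2 gives -94%, the lowest of the three numbers, beyond the scatter from both others.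

Compound 4, `COc1cc(C(=O)/C=C/c2cc(-c3cc(OC)c(OC)c(OC)c3)n[nH]2)cc(OC)c1OC`, is not yet measured. It stands to compound 2 as compound 3 stands to compound 1, by the same kind of change, (methoxy in place of hydrogen on an aromatic carbon), though here the position is also meta to a methoxy group. Compound 4 is expected to give about -96% in this assay, between -100% and -85%. That rests on the modest step of a number 12 percentage points lower from compound 1 to compound 3 (beyond the scatter), tempered by compound 2 already standing at -94%, so the expected step is a number 2 percentage points lower from compound 2 to compound 4 (within the scatter).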

Compound 4, a percentage reported as activity, at one concentration (the size of the read-out at that concentration, not a potency): -80%
Compound 4: middle estimate off by 16 percentage points, on the low side; measured number above the stated range.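

In this assay, methoxy in place of hydrogen on an aromatic carbon gives a number 14 percentage points higher from compound 2 to compound 4 (beyond the scatter), so the direction seen on the core of compound 1 does not carry over to the core of compound 2. Set side by side, the two steps differ: the same change on two cores in this assay, a number 12 percentage points lower (beyond the scatter) from compound 1 to compound 3 and a number 14 percentage points higher (beyond the scatter) from compound 2 to compound 4, 26 percentage points apart, beyond the scatter of two such steps. This shows that a step read on one of these cores cannot simply be transferred to the other, but it does not show why they part, since the cores differ in more than one place and the methoxy on compound 4 also sits meta to a methoxy group, and a single pair on each core gives no rule for any further core.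

The compounds shown leave open whether a hydroxyl, a fluorine or a longer alkoxy chain at the same place would follow either step. They also leave open whether a carboxylic acid there would keep the read-out near that of compound 2 or compound 4.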